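The source may report more compounds than this note shows. Statements on the series, on what has been measured and on what is new or still open speak of the compounds shown alone.

In a functional assay on K562 cells (Homo sapiens) for cytotoxicity, read by MTT assay, with a stated time of 72 h (a lower number here means a stronger inhibitor, a higher number a weaker inhibitor), compound 1 `CC1=CCC[C@H]2[C@](C)(CC3=CC(=O)C=CC3=O)[C@@H](C)CC[C@]12C` gives 17100 nM and compound 2 `CC1=CCC[C@H]2[C@](C)(CC3=CC(=O)C=C(NCCC(=O)O)C3=O)[C@@H](C)CC[C@]12C` gives 15500 nM so the two stand level within the scatter. Compound 3 `CC1=CCC[C@H]2[C@](C)(CC3=CC(=O)C=C(NCC(=O)O)C3=O)[C@@H](C)CC[C@]12C` departs from compound 2 by one change, carboxy in place of carboxymethyl on a saturated chain carbon bound to an amine nitrogen. The count of that change reads carboxy in place of carboxymethyl on a saturated chain carbon bound to an amine nitrogen and nothing else differs. Among the compounds with values here, the one measured step bearing on it is a 1.1-fold lower number from compound 1 to compound 2 (0.04 log units; within the scatter) and it came with the whole (2-carboxyethyl)amino group, so no step beyond the scatter is expected in this assay from this smaller change. The expected step is a 1.0-fold higher number from compound 2 to compound 3 (0.01 log units; within the scatter) as estimated here. For compound 3 the estimated value is 16000 nM and the expected range runs from 9000 nM as lower end to 30000 nM as upper end.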

Compound 3, half-maximal inhibitory concentration: 15600 nM
The estimate for compound 3 lay 1.0-fold (0.01 log units) above the measured number; the measured number falls inside the stated range.
By their numbers in this assay, from the lowest: compounds 2, 3 and 1 (each within the scatter of the next).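

In this assay the shorter chain changes nothing that can be read, with a 1.0-fold higher number from compound 2 to compound 3 (0.00 log units; within the scatter) for the swap from 2-carboxyethyl to carboxymethyl. The (carboxymethyl)amino group also stands level with hydrogen on the double-bonded ring carbon, with a 1.1-fold lower number from compound 1 to compound 3 (0.04 log units; within the scatter) as its step, so both chain lengths ending in a carboxylic acid now read alike at this place. No evidence here bears on why the numbers stay level. On these data alone, whether an ester, an amide or a terminal amine on this chain, or a longer chain, would move the number beyond the scatter remains open.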